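This account rests on a few compounds, and the source may have more. Where it says the series, first, only, none or still open, it means among the compounds named here.

Measured in a functional assay on CLL cells (Homo sapiens) for cytotoxicity, read by MTT assay, with a stated time of 48 h; a lower number here means that less compound is needed, a higher number that more compound is needed for the effect:

- Compound 1 `C=C(CC)C(=O)c1ccc(OCC(=O)NCC(=O)O)c(Cl)c1Cl`: > 25000 nM, a limit of the assay and not a number
- Compound 2 `C=C(CC)C(=O)c1ccc(OCC(=O)Nc2ccc(O)c([N+](=O)[O-])c2)c(Cl)c1Cl`: 7400 nM
- Compound 3 `C=C(CC)C(=O)c1ccc(OCC(=O)Nc2ccc(C(=O)OC)cc2)c(Cl)c1Cl`: 4100 nM

Among the compounds with values here, compound 3 has one of only two actual numbers. Its value of 4100 nM lies within the usual scatter of the value for compound 2, so this assay does not separate these two compounds. Compound 1 is recorded only as a limit, > 25000 nM.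

The next compound to be tested is compound 4 `C=C(CC)C(=O)c1ccc(OCC(=O)Nc2ccc(O)cc2)c(Cl)c1Cl`. It keeps the core and the amide of compound 3, but hydroxy takes the place of methoxycarbonyl on an aromatic carbon, para to a large group: hydroxy in place of methoxycarbonyl on an aromatic carbon.

Within the data shown here, no measured pair in this small set isolates that exchange, so the expectation rests on indirect evidence. Compound 2 also bears a hydroxy on its aromatic ring and gives 7400 nM, which suggests that such a compound may remain measurable in this assay. A small upward step is expected, possibly none beyond the scatter. The expected change is a 1.6-fold higher number from compound 3 to compound 4 (0.20 log units; within the scatter). The estimated value for compound 4 is 6500 nM, with an expected range from 2500 nM to 16000 nM.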

Compound 4, half-maximal effective concentration: 6400 nM
Estimate against measurement, compound 4: 1.0-fold (0.01 log units) above, within the range that was stated.
By their numbers in this assay, from the lowest: compounds 3, 4 and 2 (each within the scatter of the next). At a limit, above all of these: compound 1.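

In this assay, within the data shown here, the exchange at this aromatic carbon gives the first direct pair for this place, and hydroxy in place of methoxycarbonyl amounts to a 1.6-fold higher number from compound 3 to compound 4 (0.19 log units; within the scatter), so this assay does not separate the two groups. Hydrogen in place of nitro on an aromatic carbon gives a 1.2-fold lower number from compound 2 to compound 4 (0.06 log units; within the scatter), so the nitro group of compound 2 also makes no difference that this assay can resolve. The only step beyond the scatter lies on the amide-type nitrogen, where 4-hydroxyphenyl in place of carboxymethyl gives an at least 3.9-fold lower number from compound 1 to compound 4 (0.59 log units; beyond the scatter), and its size is only a lower bound, as compound 1 stands at a limit of the assay: the limit of > 25000 nM in this assay, at which 1 of the 4 values shown sits.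

It remains open whether any group on this aromatic carbon would move the number beyond the scatter, as an amine or a carboxylic acid there is not among the compounds shown. Going by these compounds, it is also open how much of the step on the amide-type nitrogen goes with the aromatic ring and how much with the loss of the carboxylic acid, since a longer chain ending in a methyl ester or an unsubstituted phenyl is not among them either.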